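Swapping bromo for methyl on a shared anilino-thioether core

The source may hold more compounds than are shown below. What is called first, only, known or untested is meant among the compounds shown, and "the series" means these compounds.

Measured compounds:
Compound 1 `C=CC(=O)Nc1cccc(NC(=O)CSc2nc(Nc3ccccc3)c3ccccc3n2)c1` gives 8120 nM in a functional assay on NCI-H1975 cells (Homo sapiens) for inhibition, read by MTT assay, with a stated time of 72 h; on this read-out higher numbers stand for weaker inhibition and lower numbers for stronger inhibition.
Compound 2 `C=CC(=O)Nc1cccc(NC(=O)CSc2nc(Nc3cccc(Cl)c3)c3ccccc3n2)c1` gives 9460 nM in this assay.
Compound 3 `C=CC(=O)Nc1cccc(NC(=O)CSc2nc(Nc3cccc(Br)c3)c3ccccc3n2)c1` gives 12100 nM in this assay.

Compound 3 carries the highest of the three numbers, yet its neighbours sit close: the step of a 1.3-fold higher number from compound 2 to compound 3 (0.11 log units; within the scatter) and the step of a 1.5-fold higher number from compound 1 to compound 3 (0.17 log units; within the scatter) both stay within the scatter, so the three compounds cannot be told apart on these data.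

Compound 4 `C=CC(=O)Nc1cccc(NC(=O)CSc2nc(Nc3cccc(C)c3)c3ccccc3n2)c1` is the unmeasured member. Its difference from compound 3 reads (methyl in place of bromo on an aromatic carbon), on the ring attached to the amine, at a position meta to a large group.

Within the data shown here, two measured steps touch the same position: a 1.2-fold higher number from compound 1 to compound 2 (0.07 log units; within the scatter) and a 1.5-fold higher number from compound 1 to compound 3 (0.17 log units; within the scatter), both hydrogen replaced by a halogen, and neither moves beyond the scatter. Among the measured compounds shown here, no measured step puts a methyl at that position, so the methyl itself has no precedent here. What the series does show is that this position tolerates hydrogen, chloro and bromo alike without a clear change in this assay.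

Compound 4 is therefore expected to stay near compound 3, with an estimated step of a 1.3-fold lower number from compound 3 to compound 4 (0.11 log units; within the scatter), no larger than the scatter. The estimate for compound 4 is 9500 nM, within a range from 4500 nM to 20000 nM.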

Compound 4, half-maximal inhibitory concentration: 12100 nM
The estimate for compound 4 lay 1.3-fold (0.11 log units) below the measured number; low and high end bracket the measured number.
By their numbers in this assay, from the lowest: compounds 1, 2, 3 and 4 (each within the scatter of the next).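

The methyl group adds a carbon substituent to the hydrogen, chloro and bromo already seen at this position, and in this assay the series gives no change at the digits printed from compound 3 to compound 4 (within the scatter) along with a 1.3-fold higher number from compound 2 to compound 4 (0.11 log units; within the scatter) and also a 1.5-fold higher number from compound 1 to compound 4 (0.17 log units; within the scatter) for the three possible comparisons. All four compounds therefore cannot be told apart in this assay, so the lack of a clear shift now extends beyond the halogens to a single-carbon group, and swapping bromo for methyl leaves the read-out where it was. The data offer no measurement that would explain why these replacements make so little difference here.

On these data alone, every group compared at this position is either hydrogen or a substituent with one heavy atom, so it remains open whether an amine, a carboxylic acid or a longer chain such as propyl would also leave the number within the scatter. As far as these compounds go, it also remains open whether any substituent at this position can separate itself from compound 1 in this assay, since none of the four compounds does.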